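The source may report more compounds than this note shows. Statements on the series, on what has been measured and on what is new or still open speak of the compounds shown alone.

Measured so far:
- compound 1, `Cn1c(COc2cccc(C(=O)O)c2)nc2cnc(Oc3ccc(Cl)c(F)c3)cc21` — 11.2 10^-6 cm/s
- compound 2, `Cn1c(COc2cccc(C(=O)O)c2)nc2ccc(Oc3ccc(Cl)cn3)cc21` — 16.2 10^-6 cm/s

Both compounds were run in an ADME assay for permeability, using PAMPA, with a stated time of 4 h; on this read-out lower numbers stand for lower permeability and higher numbers for higher permeability. Compound 2 stands at the top of the two numbers, but its gap to compound 1 lies within the usual scatter of repeated measurements, so the two results cannot be told apart.

The next compound is compound 3, `Cn1c(COc2cccc(C(=O)O)c2)nc2ccc(Oc3ncccc3F)cc21`. It differs from compound 2 in one place: 3-fluoropyridin-2-yl in place of 5-chloropyridin-2-yl on an oxygen on an aromatic ring. Both groups that change are six-membered aromatic rings carrying one nitrogen and one halogen, so the overall size and shape of that part of the molecule barely moves; only the halogen and its place on the ring change.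

For the measured compounds named here, no measured step between two compounds covers this kind of change, so there is nothing to calibrate against. In this assay the step from compound 2 to compound 3 is expected to be small, most likely a slight fall, and not beyond the scatter, giving a 1.4-fold lower number from compound 2 to compound 3 (0.13 log units; within the scatter). Compound 3 is therefore estimated at 12 10^-6 cm/s, with a range from 6 10^-6 cm/s to 24 10^-6 cm/s.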

Compound 3, apparent permeability: 3.9 10^-6 cm/s
Beside the measured number, compound 3's estimate is 3.1-fold (0.49 log units) above it; measured number outside the range, below it.
By their numbers in this assay, from the lowest: compound 3; then compounds 1 and 2 (each within the scatter of the next).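

In this assay, the group on the oxygen on an aromatic ring turns out to matter, with the swap of 5-chloropyridin-2-yl for 3-fluoropyridin-2-yl giving a 4.2-fold lower number from compound 2 to compound 3 (0.62 log units; beyond the scatter). The two groups match in every count computed for them, with the same number of heavy atoms, the same kind of six-membered aromatic ring, the same hydrogen-bond donor and acceptor counts and no net charge, so a change that leaves these counts untouched can still shift this read-out clearly. Nothing measured here explains the fall, so its cause stays unknown.

This single step replaces chlorine with fluorine and moves the halogen on the ring at the same time, and the compounds shown do not separate these two changes. They also leave open how this read-out would respond to a pyridin-2-yl ring with no halogen, or to a ring carrying a methyl group or a nitrile in place of the halogen.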